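This account rests on a few compounds, and the source may have more. Where it says the series, first, only, none or still open, it means among the compounds named here.

Measured in an assay on cells for inhibition of phosphatidylcholine:ceramide cholinephosphotransferase 2 (Homo sapiens), read by mass spectrometry, with stated times of 60 min and 30 min; on this read-out lower numbers stand for stronger inhibition and higher numbers for weaker inhibition:

- compound 1 `CCCOc1c(C(=O)N(C)Cc2cc(C(F)(F)F)cc(C(F)(F)F)c2)c(=O)n(C)c2ccccc12`: 2100 nM
- compound 2 `CC(C)CCOc1c(C(=O)N(C)Cc2cc(C(F)(F)F)cc(C(F)(F)F)c2)c(=O)n(C)c2ccccc12`: 350 nM
- compound 3 `CN(Cc1cc(C(F)(F)F)cc(C(F)(F)F)c1)C(=O)c1c(N2CCCCC2)c2ccccc2n(C)c1=O`: 11000 nM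

Compound 3 gives the highest number of the three; the nearest is compound 1 and the furthest is compound 2, both steps beyond the scatter. The next compound, compound 4 `CN(Cc1cc(C(F)(F)F)cc(C(F)(F)F)c1)C(=O)c1c(OCCCC(F)(F)F)c2ccccc2n(C)c1=O`, differs from compound 3 in one place: 4,4,4-trifluorobutoxy in place of piperidin-1-yl on an aromatic carbon.

Among the compounds with values here, two measured steps bear on this. Piperidin-1-yl in place of propoxy gave a 5.2-fold higher number from compound 1 to compound 3 (0.72 log units; beyond the scatter), and piperidin-1-yl in place of isopentyloxy gave a 31-fold higher number from compound 2 to compound 3 (1.50 log units; beyond the scatter). Compound 4 runs the opposite way, back to a chain on an oxygen as in compound 1 and compound 2; the 4,4,4-trifluorobutoxy chain falls between propoxy and isopentyloxy in length. A drop in this assay of similar size, somewhere between those two steps, is therefore expected, with the direction clearer than the amount. Compound 4 is estimated at 700 nM, within 200 nM to 2500 nM, meaning an expected step of a 16-fold lower number from compound 3 to compound 4 (1.20 log units; beyond the scatter).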

Compound 4, half-maximal inhibitory concentration: 120 nM
For compound 4 the middle estimate is 5.8-fold (0.77 log units) above the measured one, outside the stated range (below it).
By their numbers in this assay, from the lowest: compound 4; then compound 2; then compound 1; then compound 3.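

Within the data shown here, replacing piperidin-1-yl with 4,4,4-trifluorobutoxy on this aromatic carbon gives a 92-fold lower number from compound 3 to compound 4 (1.96 log units; beyond the scatter) in this assay and is the largest step so far, leaving compound 4 with the lowest number of the four. The chain end also matters here, beyond the oxygen link alone: trifluoromethyl in place of hydrogen gives an 18-fold lower number from compound 1 to compound 4 (1.24 log units; beyond the scatter) and 2,2,2-trifluoroethyl in place of isopropyl gives a 2.9-fold lower number from compound 2 to compound 4 (0.46 log units; beyond the scatter) as a further, modest drop. No measurement available here accounts for the effect of this chain end.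

Open, on these data alone, is how much of the step belongs to the fluorine atoms and how much to chain length, which a plain butoxy chain would separate. Also open, as far as these compounds go, is how far the trend runs, for example with a longer chain such as 5,5,5-trifluoropentyloxy or with a hydroxyl at the chain end.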